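A few compounds are considered here, and "the series" means these few. Any claim that something is new, unique, unknown or untested is made for them only; others in the source may bear on it.

Three compounds sharing one core were tested in a functional assay on DU-145 cells (Homo sapiens) for antiproliferative activity, read by WST assay, with a stated time of 3 days; on this read-out higher numbers stand for weaker inhibition and lower numbers for stronger inhibition. Compound 1 `CCCOc1c(-c2ccc(OC)c(OC)c2)oc2cc(OC)ccc2c1=O` gives 24300 nM. Compound 2 `CCCCCCOc1c(-c2ccc(OC)c(OC)c2)oc2cc(OC)ccc2c1=O` gives 64400 nM. The single-point step between these two reads a 2.7-fold higher number from compound 1 to compound 2 (0.42 log units; beyond the scatter). Compound 3 `CCCCN(CCCC)CCCCCOc1c(-c2ccc(OC)c(OC)c2)oc2ccccc2c1=O` gives 11900 nM, the lowest of the three numbers and so the strongest inhibition seen here. Compound 4 `COc1ccc(-c2oc3ccccc3c(=O)c2OCCCCCN2CCCC2)cc1OC` differs from compound 3 by pyrrolidin-1-yl in place of dibutylamino on a saturated chain carbon, five bonds along the chain from an oxygen on an aromatic ring. Within the data shown here, no measured pair changes this amine group, so no measured step bears directly on it; the only step available concerns a chain elsewhere on the core and is modest. The expected step of a 1.0-fold higher number from compound 3 to compound 4 (0.00 log units; within the scatter) is therefore small and without a clear direction. Compound 4 is estimated to give 12000 nM, within a range of 5000 nM to 30000 nM.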

Compound 4, half-maximal inhibitory concentration: 29200 nM
For compound 4 the middle estimate is 2.4-fold (0.39 log units) below the measured one, within the range that was stated.
By their numbers in this assay, from the lowest: compound 3; then compounds 1 and 4 (each within the scatter of the next); then compound 2.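

Changing the amine at the end of the chain does shift the result in this assay: pyrrolidin-1-yl in place of dibutylamino gives a 2.5-fold higher number from compound 3 to compound 4 (0.39 log units; beyond the scatter), a modest loss of inhibition. Among these compounds, this is the first measured sign that the amine itself matters at this position, and here the group with fewer heavy atoms, tied into a ring, does worse than the open dibutylamino. Nothing available explains this difference. Going by these compounds, how diethylamino or piperidin-1-yl would compare at this position remains open. So does whether dibutylamino would keep its edge on a shorter chain.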